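Ethynyl Added to the Anilide of Compound 2

A few compounds are considered here, and "the series" means these few. Any claim that something is new, unique, unknown or untested is made for them only; others in the source may bear on it.

Compound 1 `O=C(O)CCc1cccc2c1B(O)OC2`: in a functional assay on SK-OV-3 cells (Homo sapiens) for antiproliferative activity, read by MTT assay, with a stated time of 72 h (on this read-out lower numbers stand for stronger inhibition and higher numbers for weaker inhibition), compound 1 gives > 100000 nM, a limit of the assay.
Compound 2 `O=C(CCc1cccc2c1B(O)OC2)Nc1ccccc1`: compound 2 gives 200 nM.
Compound 3 `O=C(CCc1cccc2c1B(O)OC2)Nc1nccs1`: compound 3 gives > 100000 nM, again a limit.

Among the measured compounds shown here, compound 2 thus stands as the only real number in this assay; the other two values are limits (the limit of > 100000 nM in this assay, at which 2 of the 3 values shown sit). Compound 4 `C#Cc1ccc(NC(=O)CCc2cccc3c2B(O)OC3)cc1` differs from compound 2 by ethynyl in place of hydrogen on an aromatic carbon. The measured steps both replace the whole group on the amide-type nitrogen: an at least 500-fold lower number from compound 1 to compound 2 (2.69 log units; beyond the scatter) and an at least 500-fold higher number from compound 2 to compound 3 (2.69 log units; beyond the scatter). Neither touches a substituent on the phenyl, so they bear on the new change only in showing that this region is sensitive. Compound 4 is therefore expected to remain near compound 2, with a 1.1-fold lower number from compound 2 to compound 4 (0.05 log units; within the scatter) not beyond the scatter, at an estimated 180 nM (range 40 nM to 900 nM).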

Compound 4, half-maximal inhibitory concentration: 6300 nM
Estimate against measurement, compound 4: 35-fold (1.54 log units) below, outside the stated range (above it).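

The earlier steps shown here exchanged the whole group on the amide-type nitrogen, whereas this one keeps the phenyl and still gives a 32-fold higher number from compound 2 to compound 4 (1.50 log units; beyond the scatter) on adding only ethynyl, para to a large group. Even a substituent of 2 heavy atoms at this place therefore matters, so the sensitivity reaches beyond the choice of ring. Nothing shown gives a cause for this step.

The compounds shown leave open whether a fluorine atom, a methoxy group or an amine at this place would cost as much. They also leave open whether a longer chain ending in the triple bond would differ from ethynyl.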